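Two Limits Ahead of a Cyclopropyl Ethenyl Amide

A few compounds are considered here, and "the series" means these few. Any claim that something is new, unique, unknown or untested is made for them only; others in the source may bear on it.

In a functional assay on MCF7 cells (Homo sapiens) for inhibition, read by sulforhodamine B assay, with a stated time of 72 h (a higher number here means a weaker inhibitor of growth, a lower number a stronger inhibitor of growth), compound 1 (`O=C(CCc1ccncc1-c1ccc2ccccc2c1)N1CCOCC1`) gives > 10000 nM, which is a limit. Compound 2 (`CNC(=O)CCc1ccncc1-c1ccc2ccccc2c1`) gives > 10000 nM, again a limit. Going by the values given here, the one measured step is a step that the two limits leave unreadable from compound 1 to compound 2, and the evidence is the limit of > 10000 nM in this assay, at which 2 of the 2 values shown sit. Compound 3 (`O=C(/C=C/c1ccncc1-c1ccc2ccccc2c1)NC1CC1`) carries 2-(cyclopropylcarbamoyl)ethenyl in place of 2-(methylcarbamoyl)ethyl on an aromatic carbon. Among the compounds with values here, no measured step gives a size or direction for this change, so no step beyond the scatter is expected in this assay. The expected step is a number no higher from compound 2 to compound 3 (the limit leaves the size open). For compound 3 the estimate is 10000 nM, with an expected range of 3000 nM to 30000 nM.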

Compound 3, concentration for 50% growth inhibition: 6840 nM
Compound 3: middle estimate off by 1.5-fold (0.16 log units), on the high side; low and high end bracket the measured number.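

In this assay, compound 3 is the only one of the three compounds shown to give a number rather than a limit, which makes 2-(cyclopropylcarbamoyl)ethenyl on this aromatic carbon, opposite the ring nitrogen, the one readable case at this position. The change appears as an at least 1.4-fold lower number from compound 2 to compound 3 (0.16 log units; that floor lies within the scatter), so it is not shown to exceed the scatter. The true size stays open: the limit of > 10000 nM in this assay, at which 2 of the 3 values shown sit.

The change joins an ethenyl link and a cyclopropyl group, and the compounds shown do not separate the two. Going by these compounds, whether a carboxylic acid or a longer chain here would give a lower number also remains open.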